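From a 3-bromophenyl to a 4-cyanophenyl amide

A few compounds are considered here, and "the series" means these few. Any claim that something is new, unique, unknown or untested is made for them only; others in the source may bear on it.

Measured in a functional assay on MGC-803 cells (Homo sapiens) for inhibition, read by MTT assay, with a stated time of 72 h; a higher number here means a weaker inhibitor, a lower number a stronger inhibitor:
compound 1 `Cc1ccc(NC(=O)C2CCN(C/C=C/c3ccccc3)CC2)cc1`: 24100 nM
compound 2 `O=C(Nc1cccc(F)c1)C1CCN(C/C=C/c2ccccc2)CC1`: 23300 nM
compound 3 `O=C(Nc1cccc(Br)c1)C1CCN(C/C=C/c2ccccc2)CC1`: 9110 nM

Compound 3 has the lowest number of the three at 9110 nM, and its steps to both others lie beyond the scatter. The next compound is compound 4 `N#Cc1ccc(NC(=O)C2CCN(C/C=C/c3ccccc3)CC2)cc1`, in which the group on the amide-type nitrogen changes: 4-cyanophenyl in place of 3-bromophenyl on an amide-type nitrogen. For the measured compounds named here, no measured compound carries a nitrile, so this swap has no direct precedent. Two modest measured steps bear on it: a 2.6-fold lower number from compound 1 to compound 3 (0.42 log units; beyond the scatter) and a 2.6-fold lower number from compound 2 to compound 3 (0.41 log units; beyond the scatter). A third, a 1.0-fold lower number from compound 1 to compound 2 (0.01 log units; within the scatter), shows no separation between the two compounds that lack bromo. Going by the values given here, compound 3 is the only measured compound with bromo, and removing that group is expected to give back part of its advantage in this assay. The expected change is a 1.9-fold higher number from compound 3 to compound 4 (0.27 log units; within the scatter). For compound 4 the estimated value is 17000 nM, with an expected range from 7000 nM to 40000 nM.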

Compound 4, half-maximal inhibitory concentration: 28200 nM
Beside the measured number, compound 4's estimate is 1.7-fold (0.22 log units) below it; the range from low to high includes it.
By their numbers in this assay, from the lowest: compound 3; then compounds 2, 1 and 4 (each within the scatter of the next).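

The nitrile does not keep the advantage of the 3-bromophenyl group in this assay (a 3.1-fold higher number from compound 3 to compound 4 (0.49 log units; beyond the scatter)). The 4-cyanophenyl amide instead shows no separation from the 3-fluorophenyl amide (a 1.2-fold higher number from compound 2 to compound 4 (0.08 log units; within the scatter)) or from the 4-methylphenyl amide (a 1.2-fold higher number from compound 1 to compound 4 (0.07 log units; within the scatter)). Across these changes on the amide-type nitrogen, the cyano, fluoro and methyl compounds cannot be told apart in this assay, and only the bromo compound stands alone, so the separation now rests on a single compound against three.

Nothing at hand gives a reason for that separation. From the compounds shown here alone, whether it follows bromo itself or the place it occupies stays open, and a 4-bromophenyl or a 3-chlorophenyl amide would speak to that question.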